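Amide aryl variation in a fluoropyridinyl pyrazolo-piperazine series

The compounds below may be only part of what the source reports. "The series", "measured", "known", "first", "only" and "open" are said of these compounds alone.

Measured compounds:
Compound 1, `O=C(c1ccccc1)N1CCn2nc(-c3ccc(F)cn3)cc2C1`, gives 164 nM in a functional assay on HEK293 cells for negative allosteric modulation of metabotropic glutamate receptor 5 (Homo sapiens), read by calcium flux, with a stated time of 20 min; on this read-out lower numbers stand for stronger inhibition and higher numbers for weaker inhibition.
Compound 2, `O=C(c1cccc(F)c1)N1CCn2nc(-c3ccc(F)cn3)cc2C1`, gives 257 nM in this assay.
Compound 3, `COc1cccc(C(=O)N2CCn3nc(-c4ccc(F)cn4)cc3C2)c1`, gives 482 nM in this assay.

Compound 3 stands with the highest number of the three. Its distance to compound 2 is within the scatter, while the step of a 2.9-fold higher number from compound 1 to compound 3 (0.47 log units; beyond the scatter) is a modest one beyond it. Compound 4, `Cc1cc(F)cc(C(=O)N2CCn3nc(-c4ccc(F)cn4)cc3C2)c1`, is obtained by the change (3-fluoro-5-methylphenyl in place of 3-methoxyphenyl on a carbonyl carbon). Within the data shown here, two measured steps bear on this change. The step of a 1.9-fold higher number from compound 2 to compound 3 (0.27 log units; within the scatter) shows that replacing fluoro by methoxy moved the number only within the scatter, and the step of a 1.6-fold higher number from compound 1 to compound 2 (0.20 log units; within the scatter) shows that fluoro in place of hydrogen did the same. Among the measured compounds shown here, compound 4 restores the fluoro seen in compound 2 and adds a methyl on the same ring, a change for which no measured pair exists. Compound 4 is therefore expected to return to a number close to that of compound 2, with the step of a 1.6-fold lower number from compound 3 to compound 4 (0.21 log units; within the scatter) estimated to stay near the edge of the scatter. Compound 4 is estimated at 300 nM in this assay, between 120 nM and 750 nM.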

Compound 4, half-maximal inhibitory concentration: 197 nM
Compound 4: the middle estimate sits 1.5-fold (0.18 log units) above what was measured; the range from low to high includes it.
By their numbers in this assay, from the lowest: compounds 1, 4, 2 and 3 (each within the scatter of the next, the first and the last beyond it).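

In this assay the exchange of 3-methoxyphenyl for 3-fluoro-5-methylphenyl on a carbonyl carbon gives a 2.4-fold lower number from compound 3 to compound 4 (0.39 log units; beyond the scatter) and so moves the number beyond the scatter, which neither of the earlier single exchanges of fluoro and methoxy on the ring did from compound 2. Adding a methyl to the fluorinated ring gives a 1.3-fold lower number from compound 2 to compound 4 (0.12 log units; within the scatter) and the full change from phenyl gives a 1.2-fold higher number from compound 1 to compound 4 (0.08 log units; within the scatter) and both stay within the scatter, so among these compounds this ring carries a second substituent with no measurable cost. Compound 3 therefore still stands beyond the scatter from compound 1 and compound 4, although its distance to compound 2 remains within it, which leaves the methoxy compound apart only in part.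

The compounds shown leave open how a ring bearing the methyl without the fluoro would read, and whether a nitrile, a trifluoromethyl, an amine or a carboxylic acid would be accepted at this ring. They also give no step that falls beyond the scatter below compound 1, and no measurement offered here accounts for any of these numbers.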